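Series notes: from compound 3 to compound 4

The compounds below may be only part of what the source reports. "The series", "measured", "known", "first", "only" and "open" are said of these compounds alone.

Three measured compounds share one core. Compound 1 `S=C(N/N=C/c1ccc2ccccc2n1)Nc1ccc(Br)cc1` carries a 4-bromophenyl on the amide-type nitrogen, and in a functional assay on SGC-7901 cells (Homo sapiens) for antiproliferative activity, read by sulforhodamine B assay, with a stated time of 72 h (a lower number here means a stronger inhibitor, a higher number a weaker inhibitor), compound 1 gives 69400 nM. Compound 2 `FC(F)(F)c1ccccc1NC(=S)N/N=C/c1ccc2ccccc2n1` carries a trifluoromethyl on the phenyl ring in place of bromo, and in this assay compound 2 gives 20700 nM. Compound 3 `S=C(N/N=C/c1ccc2ccccc2n1)Nc1ccccc1Br` carries a 2-bromophenyl. In this assay compound 3 reaches only an assay limit, > 100000 nM. Compound 3 thus stands at the weak end of the shown numbers, known only through (the limit of > 100000 nM in this assay, at which 1 of the 3 values shown sits).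

Two measured steps lead into compound 3: an at least 1.4-fold higher number from compound 1 to compound 3 (0.15 log units; that floor lies within the scatter) and an at least 4.8-fold higher number from compound 2 to compound 3 (0.68 log units; beyond the scatter).

Compound 4 `COc1ccc(NC(=S)N/N=C/c2ccc3ccccc3n2)cc1` is the next entry. (4-methoxyphenyl in place of 2-bromophenyl on an amide-type nitrogen). The change relates to compound 1, whose substituent sits on the same ring position as the methoxy of compound 4; the step of an at least 1.4-fold higher number from compound 1 to compound 3 (0.15 log units; that floor lies within the scatter) ran in the weakening direction, so the reverse move is expected to recover at least that much. Among the measured compounds shown here, no measured step covers methoxy against bromo, so the estimate stays near the level of compound 1. For compound 4 the expected step in this assay is an at least 1.6-fold lower number from compound 3 to compound 4 (0.22 log units; that floor lies within the scatter). The estimate for compound 4 is 60000 nM, within 20000 nM to 150000 nM.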

Compound 4, half-maximal inhibitory concentration: 89600 nM
The estimate for compound 4 lay 1.5-fold (0.17 log units) below the measured number, and the stated range covers the measured number.
By their numbers in this assay, from the lowest: compound 2; then compounds 1 and 4 (each within the scatter of the next). At a limit, above all of these: compound 3.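

In this assay, 4-methoxyphenyl in place of 4-bromophenyl on the amide-type nitrogen gives a 1.3-fold higher number from compound 1 to compound 4 (0.11 log units; within the scatter), so this pair of groups is not told apart at this place on the shared core. Among the compounds shown here, this is the first comparison in which the group on the phenyl ring changes while its number in the name stays the same, and it holds for this one pair only. The change from 2-bromophenyl to 4-methoxyphenyl gives an at least 1.1-fold lower number from compound 3 to compound 4 (0.04 log units; that floor lies within the scatter), and since both the substituent and the number in the group's name change, it cannot assign any difference to either, while compound 3 is known only through an assay limit, which makes this step a floor: the limit of > 100000 nM in this assay, at which 1 of the 4 values shown sits.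

Still open, from the compounds shown here alone, is whether an amine or a carboxylic acid in place of the methoxy of compound 4 would move the number beyond the scatter relative to compound 1. Going by these compounds, a longer chain on the oxygen of that methoxy, such as an ethoxy or butoxy group, is equally open.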